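Toward a dodecyl amine on the coumarin-derived aminopropanol scaffold

This account rests on a few compounds, and the source may have more. Where it says the series, first, only, none or still open, it means among the compounds named here.

Measured compounds:
compound 1, `O=c1cc(OCC(O)CNC2CC2)c2ccccc2o1`: > 100000 nM
compound 2, `O=C(O)CCCNCC(O)COc1cc(=O)oc2ccccc12`: "not determined" (no result reported)

In an ADME assay on Vero cells (Chlorocebus sabaeus) for cytotoxicity, read by fluorescence and resazurin assay, with a stated time of 72 h (a lower number here means that less compound is tolerated, a higher number that more compound is tolerated), compound 1 gives > 100000 nM, which is a limit of the assay rather than a number. Compound 2 carries a carboxybutyl chain on the amine nitrogen of the same aminopropanol-ether core, and in this assay compound 2 gives "not determined" (no result reported), so no number places it on the scale. The only value shown among these two compounds is the limit described by the limit of > 100000 nM in this assay, at which 1 of the 2 values shown sits, and compound 2 therefore stands nowhere yet in this assay.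

Compound 3, `CCCCCCCCCCCCNCC(O)COc1cc(=O)oc2ccccc12`, is the still unmeasured partner: the change is nonyl in place of carboxy on a saturated chain carbon, three bonds along the chain from an amine nitrogen. Going by the values given here, no measured step pairs with this change. The expectation is that compound 3 will return a lower number in this assay than the limit that compound 1 reaches, a step larger than the ordinary scatter and in the direction of less compound being tolerated. Compound 3 is estimated at 30000 nM, with a range from 6000 nM to 100000 nM.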

Compound 3, half-maximal cytotoxic concentration: > 100000 nM
Compound 3: a limit, no number (the forecaster's own chance of this, stated with the estimate: 25%); middle value at least 3.3-fold (0.52 log units) away from the limit.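

In this assay compound 3 gives > 100000 nM, which is a limit of the assay and not a number. Going by these compounds alone, compound 2 gives "not determined" (no result reported), so no step from compound 2 to compound 3 can be read. The compounds shown leave open where compound 1 and compound 3 truly lie on the scale, and what nonyl in place of carboxy does in this assay: the limit of > 100000 nM in this assay, at which 2 of the 3 values shown sit.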